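This account rests on a few compounds, and the source may have more. Where it says the series, first, only, none or still open, it means among the compounds named here.

Measured so far:
compound 1 `CCCCC1=Nc2ccccc2S(=O)(=O)N1Cc1ccc(-c2ccccc2C(=O)O)cc1` — 0.117 h
compound 2 `CCCCC1=NS(=O)(=O)c2ccccc2N1Cc1ccc(-c2ccccc2C(=O)O)cc1` — > 24 h

In an ADME assay for pharmacokinetics (a higher number here means that the compound lasts longer, a lower number that the compound disappears faster), compound 1 gives 0.117 h, the only plain number among the two results shown. For compound 2 the assay reports a limit rather than a number, > 24 h, so compound 2 sits at the limit of > 24 h in this assay, at which 1 of the 2 values shown sits. Compound 3 `CCCSC1=Nc2ccccc2S(=O)(=O)N1Cc1ccc(-c2ccccc2C(=O)O)cc1` differs from compound 1 by propylsulfanyl in place of butyl on a carbon with a double bond to nitrogen. Among the compounds with values here, no measured pair isolates this change, so the step of a 1.1-fold lower number from compound 1 to compound 3 (0.03 log units; within the scatter) is expected to stay within the usual scatter of this assay. Compound 3 is therefore expected to give 0.11 h, with a range from 0.03 h to 0.4 h.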

Compound 3, half-life: >> 24 h
Compound 3: no number, only a limit; the forecaster's own chance of this, stated with the estimate: 5%; middle value at least 210-fold (2.33 log units) from the limit.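

In this assay, the change of butyl to propylsulfanyl on this carbon, between two ring nitrogen atoms, gives an at least 200-fold higher number from compound 1 to compound 3 (2.31 log units; beyond the scatter), so the group at this position can by itself move the read-out far beyond the scatter. The size of that step is only a lower bound, as compound 3 carries a limit and not a number: the limit of >> 24 h in this assay, at which 1 of the 3 values shown sits.

As far as these compounds go, it remains open whether the sulfur atom or the chain attached to it accounts for the step. A propoxy chain or an amine on this carbon would bear on that question.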